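Aryl exchange at the ring-oxygen carbon: inhibition outlook

The compounds below may be only part of what the source reports. "The series", "measured", "known", "first", "only" and "open" are said of these compounds alone.

Two members of the series carry measurements so far. Compound 1 `CCCCCCc1ccc(-c2cc(=O)c3cc(C(=O)O)ccc3o2)cc1` and compound 2 `Cc1ccccc1-c1oc2ccc(C(=O)O)cc2c(=O)c1O` were tested in a functional assay on the whole organism (stomach) for inhibition, with Rattus norvegicus as the target, at a dose of 80 mg/kg; on this read-out lower numbers stand for less inhibition and higher numbers for more inhibition at the one dose given (going by the name of the read-out). In this assay compound 1 gives 2%, and compound 2 gives 15%. Among the measured compounds shown here, compound 2 therefore stands highest of the two numbers; its only neighbour, compound 1, sits a distance below it that lies beyond the usual scatter.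

Compound 3 `O=C(O)c1ccc2oc(-c3ccc(Cl)cc3)c(O)c(=O)c2c1` is not yet measured. It differs from compound 2 in one place: 4-chlorophenyl in place of 2-methylphenyl on an aromatic carbon. For the measured compounds named here, no measured pair shows what such an exchange does, so the data give no step size. The group that enters matches the group that leaves in heavy-atom count and in donors and acceptors, and the expectation is a change that stays within the scatter, with no fixed direction; the step estimated is no change at the digits printed from compound 2 to compound 3 (within the scatter). For compound 3 the estimate in this assay is 15%, with a range from 0% to 35%.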

Compound 3, a percentage reported as inhibition, in the whole organism at one dose (the size of the read-out at that dose, not a potency): -19%
Beside the measured number, compound 3's estimate is 34 percentage points above it; the whole stated range lies above it.
By their numbers in this assay, from the lowest: compound 3; then compound 1; then compound 2.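

In this assay the exchange of 2-methylphenyl for 4-chlorophenyl on the aromatic carbon next to the ring oxygen gives a number 34 percentage points lower from compound 2 to compound 3 (beyond the scatter), so this position responds strongly to the aryl group it carries. The two groups match in heavy-atom count and have no donors or acceptors, yet that match does not make the exchange a silent one here. Compound 3 at -19% also takes the read-out to the negative side of zero at this dose, which compound 2 at 15% does not.

This single step changes both the substituent and its place on the phenyl ring, so 2-chlorophenyl, 4-methylphenyl and unsubstituted phenyl would be needed to tell those two changes apart. No measurement among the data shown accounts for the size or direction of this step.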